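Shortening the propyl group: cytotoxicity expectation

A few compounds are considered here, and "the series" means these few. Any claim that something is new, unique, unknown or untested is made for them only; others in the source may bear on it.

Compound 1 `CCCCCCCCCCc1cc2cn([C@H]3C[C@H](O)[C@@H](CO)O3)c(=O)nc2o1` is recorded in an ADME assay on HEL cells (Homo sapiens) for cytotoxicity, with a stated time of 3 days (on this read-out higher numbers stand for lower toxicity in this test and lower numbers for higher toxicity in this test), only as a limit, >= 130000 nM; this is the limit of >= 130000 nM in this assay, at which 1 of the 2 values shown sits. Among the measured compounds shown here, compound 2 `CCCc1ccc(C#Cc2cc3cn([C@H]4C[C@H](O)[C@@H](CO)O4)c(=O)nc3o2)cc1` gives 87000 nM in this assay, the single firm number so far. Compound 3 `Cc1ccc(C#Cc2cc3cn([C@H]4C[C@H](O)[C@@H](CO)O4)c(=O)nc3o2)cc1` is not yet measured; its change from compound 2 is hydrogen in place of ethyl on a saturated chain carbon bound to an aromatic carbon. For the measured compounds named here, no measured step between compounds differing in one place is available, so the expected step is small, a 1.1-fold higher number from compound 2 to compound 3 (0.06 log units; within the scatter), within the usual scatter. Compound 3 is therefore estimated at 100000 nM, with a likely range from 50000 nM to 200000 nM.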

Compound 3, minimum cytotoxic concentration: >= 510000 nM
Compound 3: only a limit was reported (the forecaster's own chance of this, stated with the estimate: 35%); middle value at least 5.1-fold (0.70 log units) away from the limit.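

Hydrogen in place of ethyl on a saturated chain carbon bound to an aromatic carbon gives an at least 5.8-fold higher number from compound 2 to compound 3 (0.76 log units; beyond the scatter) in this assay. Among the compounds shown here, this is the first one-place step, and it shows that shortening propyl to methyl on the phenyl ring can move this read-out towards lower toxicity in this test. Compound 3 stands only as a limit: the limit of >= 510000 nM in this assay, at which 1 of the 3 values shown sits.

The compounds shown leave open whether an ethyl group at this place would read with compound 2 or with compound 3. Going by these compounds, how a butyl chain or a terminal amine would read there also stays open.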